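Aryl ketone swap on the shared core

The source may hold more compounds than are shown below. What is called first, only, known or untested is meant among the compounds shown, and "the series" means these compounds.

Two compounds of the shared core have been run in an assay for inhibition of Maternal embryonic leucine zipper kinase (Homo sapiens), read by ADP-Glo, with a stated time of 0.5 h; a higher number here means a weaker inhibitor, a lower number a stronger inhibitor. Compound 1 `CC(C)Nc1sc(C(=O)c2ccc(C#N)cc2)c(N)c1C#N` gives > 5000 nM, a limit of the assay rather than a number. Compound 2 `CC(C)Nc1sc(C(=O)c2ccncc2)c(N)c1C#N` gives > 5000 nM, again a limit. Both values sit at the limit of > 5000 nM in this assay, at which 2 of the 2 values shown sit, so compound 2 stands only at a limit in this assay, with no number of its own. Compound 3 `CC(C)Nc1sc(C(=O)c2ccco2)c(N)c1C#N` differs by furan-2-yl in place of pyridin-4-yl on a carbonyl carbon. Among the measured compounds shown here, no measured step in this assay is at hand for a change of this kind. The step from compound 2 to compound 3 is expected to be a step that the limit leaves unreadable from compound 2 to compound 3, none beyond the scatter. Compound 3 is estimated at 8000 nM, within 3000 nM to 30000 nM.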

Compound 3, half-maximal inhibitory concentration: 1350 nM
Beside the measured number, compound 3's estimate is 5.9-fold (0.77 log units) above it; the whole stated range lies above it.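

Among the compounds shown here, compound 3 is the first compound here with a number of its own in this assay, so the group on the carbonyl carbon can bring the read-out off the limit. Furan-2-yl in place of pyridin-4-yl gives an at least 3.7-fold lower number from compound 2 to compound 3 (0.56 log units; beyond the scatter). That size is only a bound, since compound 2 stands at a limit: the limit of > 5000 nM in this assay, at which 2 of the 3 values shown sit.

From the compounds shown here alone, whether the five-membered ring or the ring oxygen carries this step stays open. Also open, going by these compounds, is how a methyl-substituted furan-2-yl or a cyclohexyl group would read at this position.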